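Sulfonamide series: aryl exchange on compound 1

The source may report more compounds than this note shows. Statements on the series, on what has been measured and on what is new or still open speak of the compounds shown alone.

Measured compounds in a functional assay on MCF7 cells (Homo sapiens) for antiproliferative activity, read by sulforhodamine B assay, with a stated time of 48 h; on this read-out lower numbers stand for stronger inhibition and higher numbers for weaker inhibition:
compound 1 `O=C1NCCN1c1ccc(S(=O)(=O)Nc2ccc(F)cc2)cc1` gives 690 nM
compound 2 `CCCCOc1ccc(NS(=O)(=O)c2ccc(N3CCNC3=O)cc2)cc1` gives 870 nM

Compound 1 holds the lower of the two numbers, but the gap to compound 2 is a 1.3-fold higher number from compound 1 to compound 2 (0.10 log units; within the scatter), so the two compounds are not told apart by this read-out. Compound 3 `COc1ccccc1NS(=O)(=O)c1ccc(N2CCNC2=O)cc1` is not yet measured. It differs from compound 1 by 2-methoxyphenyl in place of 4-fluorophenyl on a sulfonamide nitrogen. Within the data shown here, the only measured step, a 1.3-fold higher number from compound 1 to compound 2 (0.10 log units; within the scatter), likewise alters the ring carried on the sulfonamide nitrogen, but it swaps one substituent for another rather than exchanging the whole aryl group; no step of the present kind is available, and the two measured values are the whole basis. Among the measured compounds shown here, with the one comparable step inside the scatter, the change to compound 3 is expected to produce no step beyond the scatter in this assay, the expected movement being a 1.2-fold higher number from compound 1 to compound 3 (0.06 log units; within the scatter). Compound 3 is therefore estimated at 800 nM, within a range of 300 nM to 2500 nM.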

Compound 3, half-maximal inhibitory concentration: 770 nM
Estimate against measurement, compound 3: 1.0-fold (0.02 log units) above; the range from low to high includes it.
By their numbers in this assay, from the lowest: compounds 1, 3 and 2 (each within the scatter of the next).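

Exchanging the whole aryl group on the sulfonamide nitrogen, with 2-methoxyphenyl in place of 4-fluorophenyl, gives in this assay a 1.1-fold higher number from compound 1 to compound 3 (0.05 log units; within the scatter), so at this position a change of the entire aryl group, and not only of a substituent on it, stays within the scatter. Among these compounds, the hydrogen-bond acceptor counted in 2-methoxyphenyl and absent from 4-fluorophenyl therefore comes with no step that this read-out can resolve. No supporting measurement bears on why the values stay this close.

As far as these compounds go, whether an amine or a carboxylic acid on the aryl group, or a saturated cyclohexyl group in its place, would produce a step beyond the scatter stays open. The compounds shown also leave open how far the values depend on the shared core, which all of them keep.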